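The compounds below may be only part of what the source reports. "The series", "measured", "known", "first", "only" and "open" are said of these compounds alone.

Working notes on the hydroxamate series.

Two members carry numbers in a functional assay on NFF cells (Homo sapiens) for antiproliferative activity; on this read-out lower numbers stand for stronger inhibition and higher numbers for weaker inhibition. Compound 1, `CN(C)c1ccc(C(=O)N[C@@H](CCCCCC(=O)NO)C(=O)NCc2ccccc2)cc1`, gives 12000 nM. Compound 2, `O=C(/C=C/c1ccccc1)N[C@@H](CCCCCC(=O)NO)C(=O)NCc1ccccc1`, gives 4010 nM. Among the measured compounds shown here, the single step recorded so far, a 3.0-fold lower number from compound 1 to compound 2 (0.48 log units; beyond the scatter), shows the exchange of the group on the carbonyl carbon moving the read-out by a modest but real margin. On the numbers shown, compound 2 stands at the lower of the two values, with compound 1 the only neighbour and separated from it by that step.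

The next compound, compound 3, `O=C(CCCCC[C@H](NC(=O)c1cccs1)C(=O)NCc1ccccc1)NO`, differs from compound 2 in one place: thiophen-2-yl in place of 2-phenylethenyl on a carbonyl carbon. For the measured compounds named here, the only step that bears on it is the one from compound 1 to compound 2, since it too alters the group on the same carbonyl carbon, and it was modest in size. Going by the values given here, no measured pair shows the thiophen-2-yl group itself, so the direction for compound 3 rests on no direct precedent. A change of similar magnitude, most likely back towards the weaker side, is therefore expected: a 2.0-fold higher number from compound 2 to compound 3 (0.30 log units; within the scatter). Compound 3 is estimated at 8000 nM, with a range from 3000 nM to 20000 nM.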

Compound 3, half-maximal inhibitory concentration: 5200 nM
Estimate against measurement, compound 3: 1.5-fold (0.19 log units) above; measured number inside the range.
By their numbers in this assay, from the lowest: compounds 2 and 3 (each within the scatter of the next); then compound 1.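

In this assay the carbonyl carbon accepts thiophen-2-yl in place of 2-phenylethenyl with a 1.3-fold higher number from compound 2 to compound 3 (0.11 log units; within the scatter) and so, at this place, neither the double bond outside aromatic rings nor the six-membered aromatic ring of 2-phenylethenyl is needed for a number at the level of compound 2. Set against 4-(dimethylamino)phenyl, the same thiophen-2-yl group gives a 2.3-fold lower number from compound 1 to compound 3 (0.36 log units; beyond the scatter) and this means two different groups now stand on the same side of compound 1, each by a modest step beyond the scatter. No measurement in hand offers an explanation for either step.

The compounds shown leave open whether the separation from compound 1 goes with the dimethylamino group or with the phenyl ring that carries it, a question that a plain phenyl on the same carbonyl carbon would address. Also open, going by these compounds, is whether a saturated ring such as cyclohexyl, or a group carrying a carboxylic acid, would stay level with compound 2 and compound 3 in this assay at this place.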